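A Trifluoromethylphenyl in Place of a Methoxyphenyl

The source may hold more compounds than are shown below. What is called first, only, known or untested is meant among the compounds shown, and "the series" means these compounds.

Compound 1 `CC1(c2ccccc2)CC(=O)N(CC(=O)N2CCN(c3ccc(Cl)cc3)CC2)C1=O`: in a functional assay on the whole organism (strain CD-1) with Mus musculus as the target, in the maximal electroshock model, with a stated time of 2 h (on this read-out lower numbers stand for an effect already at smaller amounts and higher numbers for an effect only at larger amounts of compound), compound 1 gives "not active" (no number reported).
Compound 2 `COc1ccccc1N1CCN(C(=O)CN2C(=O)CC(C)(c3ccccc3)C2=O)CC1`: in this assay compound 2 gives 300 mg/kg.

Among the compounds with values here, compound 2 thus holds the only number reported, while compound 1 gave no number at all. Compound 3 `CC1(c2ccccc2)CC(=O)N(CC(=O)N2CCN(c3cccc(C(F)(F)F)c3)CC2)C1=O` carries 3-(trifluoromethyl)phenyl in place of 2-methoxyphenyl on an amine nitrogen in a ring. Within the data shown here, no step between two measured compounds is at hand, so the effect of this change cannot be read from the data; the two aryl groups measured so far give one weak number and one failure. Compound 3 is expected to differ by no change at the digits printed from compound 2 to compound 3 (within the scatter), a step within the usual scatter. The estimate for compound 3 is 300 mg/kg, between 100 mg/kg and 600 mg/kg.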

Compound 3, minimum effective dose: 300 mg/kg
Compound 3: the middle estimate sits on the measured number at the digits printed; the range from low to high includes it.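

Within the data shown here, the step of no change at the digits printed from compound 2 to compound 3 (within the scatter) is the first that can be read at this position in this assay and it shows two aryl groups on the amine nitrogen that cannot be told apart here. The entering group counts no hydrogen-bond acceptor where the leaving group counts one, yet the numbers stay level. Nothing measured explains this result.

Compound 1 gives no number, so any step to or from it cannot be read. Going by these compounds, whether an unsubstituted phenyl or a carboxylic acid on that aromatic ring would hold this level remains open.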